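Notes on compound 4 in the cytotoxicity series

The source may hold more compounds than are shown below. What is called first, only, known or untested is meant among the compounds shown, and "the series" means these compounds.

The series is read in an ADME assay on Vero cells (Chlorocebus sabaeus) for cytotoxicity, read by resazurin assay, with a stated time of 3 days; a higher number here means a weaker inhibitor, a lower number a stronger inhibitor. Compound 1 `CCN(CC)c1cc2[nH]c(C3CCCCC3)nc2cc1NC(=O)NCc1ccccc1` reaches only the assay limit there, giving > 100 ug/mL. Compound 2 `O=C(NCc1ccccc1)Nc1cc2nc(C3CCCCC3)[nH]c2cc1N1CCCC1`, which carries pyrrolidin-1-yl in place of diethylamino on an aromatic carbon, likewise stops at the limit, with > 100 ug/mL. Compound 3 `COc1ccc(C(=O)Nc2cc3nc(C4CCCCC4)[nH]c3cc2N2CCCC2)cc1`, with 4-methoxyphenyl in place of benzylamino on a carbonyl carbon, again gives only a limit, > 100 ug/mL. The step that the two limits leave unreadable from compound 1 to compound 2 and the step that the two limits leave unreadable from compound 2 to compound 3 are therefore both unreadable, as the limit of > 100 ug/mL in this assay, at which 3 of the 3 values shown sit, records.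

Compound 4 `CCN(CC)c1cc2[nH]c(C3CCCCC3)nc2cc1NC(=O)c1ccc(Br)cc1` is not yet measured. It differs from compound 1 by 4-bromophenyl in place of benzylamino on a carbonyl carbon. The measured step that bears on it is a step that the two limits leave unreadable from compound 2 to compound 3, the same kind of exchange at the carbonyl carbon, and it gives no readable size. With every value shown sitting at the limit, no step beyond the scatter in either direction can be expected in this assay, and the most likely outcome is another limit. Compound 4 is therefore expected at 120 ug/mL, between 50 ug/mL and 300 ug/mL. The step that the limit leaves unreadable from compound 1 to compound 4 is expected to stay within the scatter.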

Compound 4, half-maximal inhibitory concentration: > 100 ug/mL
Compound 4 was reported as a limit (the forecaster's own chance of this, stated with the estimate: 70%); the middle value lies beyond the limit too.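

No new step can be read between compound 1 and compound 4, as both values are limits and neither is a number: the limit of > 100 ug/mL in this assay, at which 4 of the 4 values shown sit.

The compounds shown leave open whether any exchange at the carbonyl carbon or on the aromatic carbon changes the read-out at all, and what the true value of any of these four compounds is.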